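A Butyl Carbamate in Place of an Acetamide

A few compounds are considered here, and "the series" means these few. Any claim that something is new, unique, unknown or untested is made for them only; others in the source may bear on it.

Among the measured compounds shown here, in a functional assay on HT-29 cells (Homo sapiens) for antiproliferative activity, read by sulforhodamine B assay, with a stated time of 72 h (on this read-out lower numbers stand for stronger inhibition and higher numbers for weaker inhibition), compound 1 (`CCCCCCCOc1ccc(CCC(CO)(CO)NC(C)=O)c2ccccc12`) gives 17600 nM, the only true number available. Compound 2 (`CCCCc1ccc(Oc2ccc(CCC(CO)(CO)NC(C)=O)c3ccccc23)cc1`) reads > 80000 nM, which is a limit of the assay and not a number. Compound 3 (`CCCCCCCOc1ccc(CCC(CO)(CO)NC(=O)OCCCC)c2ccccc12`) differs from compound 1 by butoxy in place of methyl on a carbonyl carbon, so acetamido becomes (butoxycarbonyl)amino. For the measured compounds named here, the one measured step, an at least 4.5-fold higher number from compound 1 to compound 2 (0.65 log units; beyond the scatter), lies beyond the scatter, but it places 4-butylphenyl in place of heptyl on an oxygen on an aromatic ring and leaves the carbonyl carbon untouched. It therefore offers only weak guidance, and no step beyond the scatter is expected in this assay, in either direction. Compound 3 is estimated at 15000 nM, with an expected range of 5000 nM to 50000 nM. The expected change is a 1.2-fold lower number from compound 1 to compound 3 (0.07 log units; within the scatter).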

Compound 3, half-maximal inhibitory concentration: 22400 nM
The estimate for compound 3 lay 1.5-fold (0.17 log units) below the measured number, and the stated range covers the measured number.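

In this assay the change at the carbonyl carbon gives a 1.3-fold higher number from compound 1 to compound 3 (0.10 log units; within the scatter), so (butoxycarbonyl)amino can stand in place of acetamido with no change beyond the scatter. This is the first change shown at this position, and it shows that butoxy, with 5 heavy atoms against 1 for methyl, is accepted there in this assay, whereas the earlier step altered only the group on an oxygen on an aromatic ring. Nothing shown here gives a reason for this result.

From the compounds shown here alone, whether a longer chain than butoxy, or an amine or a carboxylic acid at the end of that chain, would leave the number in the same range remains open. Going by these compounds, it is also open whether (butoxycarbonyl)amino would be accepted in the setting of compound 2, whose reading is a limit of the assay and not a number.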